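The source may report more compounds than this note shows. Statements on the series, on what has been measured and on what is new or still open speak of the compounds shown alone.

Measured so far:
compound 1, `ClCc1ccccc1Cn1cnc2c(Cl)nc(Cl)nc21`, 4670 nM;
compound 2, `ClCc1cccc(Cn2cnc3c(Cl)nc(Cl)nc32)c1`, 11800 nM;
compound 3, `Nc1nc(Cl)c2ncn(Cc3ccccc3CCl)c2n1`, 19500 nM.

These values come from a functional assay on SN12C cells (Homo sapiens) for cytotoxicity, read by sulforhodamine B assay, with a stated time of 48 h; a higher number here means that more compound is tolerated, a lower number that less compound is tolerated. Compound 1 and compound 2 share the same atoms joined differently; the difference between the two cores is not broken down here. Compound 3 arises from compound 1 by one change, (amino in place of chloro on an aromatic carbon), and that change gave a 4.2-fold higher number from compound 1 to compound 3 (0.62 log units; beyond the scatter). Compound 4, `Nc1nc(Cl)c2ncn(Cc3cccc(CCl)c3)c2n1`, is not yet measured and arises from compound 2 by the same change, (amino in place of chloro on an aromatic carbon), at the same kind of place. The step from compound 2 to compound 4 is expected to be about a 3.6-fold higher number from compound 2 to compound 4 (0.55 log units; beyond the scatter), because the same change gave a 4.2-fold higher number from compound 1 to compound 3 (0.62 log units; beyond the scatter). For compound 4 the expected value in this assay is therefore 42000 nM, between 15000 nM and 110000 nM.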

Compound 4, concentration lethal to 50% of the cells: 39800 nM
For compound 4 the middle estimate is 1.1-fold (0.02 log units) above the measured one; the range from low to high includes it.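

In this assay, putting amino in place of chloro on the core of compound 2 gave a 3.4-fold higher number from compound 2 to compound 4 (0.53 log units; beyond the scatter). The change therefore carried over between these two cores, with a step of much the same size on each: the same change on two cores in this assay, a 4.2-fold higher number (0.62 log units; beyond the scatter) from compound 1 to compound 3 and a 3.4-fold higher number (0.53 log units; beyond the scatter) from compound 2 to compound 4, 1.2-fold (0.09 log units) apart, within the scatter of two such steps This rests on just two pairs of compounds in one cell line, so it does not show why the number rises or whether the step would hold on any other core.

The compounds shown leave open whether a methylamino or hydroxyl group at the same place would give a similar step. They also leave open what a methoxy group would do in place of the remaining chloro group.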